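The compounds below may be only part of what the source reports. "The series", "measured", "known", "first", "only" and "open" are said of these compounds alone.

In a functional assay on MDBK cells (Bos taurus) for cytotoxicity (on this read-out higher numbers stand for lower toxicity in this test and lower numbers for higher toxicity in this test), compound 1 `CO/N=C(\C#N)C(=O)NCC1=NOC(C(C)(C)C)C1` gives > 100 ug/mL, which is a limit of the assay and not a number. Compound 2 `CO/N=C(/C#N)C(=O)NCC1=NOC(C(C)(C)C)C1` gives > 100 ug/mL, which is also a limit. Compound 2 therefore has no number of its own, and the evidence on it is the limit of > 100 ug/mL in this assay, at which 2 of the 2 values shown sit. The two compounds differ only in the fact that one of compounds 1 and 2 is drawn with a defined configuration and the other without, at the place where they differ. Within the data shown here, the one measured step is a step that the two limits leave unreadable from compound 1 to compound 2, so it offers no size to carry forward.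

Compound 3 `C=CCO/N=C/C(=O)NCC1=NOC(C(C)(C)C)C1` has not yet been measured. It keeps the shared core and the amide, and the change is a group of 6 heavy atoms (4 carbon, 1 nitrogen, 1 oxygen; no ring) in place of a group of 6 heavy atoms (3 carbon, 2 nitrogen, 1 oxygen; no ring), on a carbonyl carbon. Among the measured compounds shown here, no measured step speaks to a change of this kind, so no shift in either direction is expected beyond the scatter in this assay, and another limit is the likeliest result. The estimated step is a number no higher from compound 2 to compound 3 (the limit leaves the size open). For compound 3 the expected value is 100 ug/mL, with an estimated range from 50 ug/mL to 200 ug/mL.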

Compound 3, half-maximal cytotoxic concentration: > 100 ug/mL
Compound 3 ended at the assay's limit; the forecaster's own chance of this, stated with the estimate: 80%; the middle value sits exactly at the limit.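

Among these compounds, compound 3, like compound 1 and compound 2, sits at a limit of the assay and not at a number, so no step to compound 3 can be read. The compounds shown leave open where the true cytotoxic concentration of each lies in this assay, and whether the exchanged group shifts it.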